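A few compounds are considered here, and "the series" means these few. Any claim that something is new, unique, unknown or untested is made for them only; others in the source may bear on it.

Measured so far:
compound 1 `COc1ccc(Oc2ccc3c(NCCCNCc4cc(F)ccc4OC)ccnc3c2)cc1` — 9.28
compound 2 `c1coc(CNCCCNc2ccnc3cc(CC4CCCCC4)ccc23)c1` — 9.47

Both compounds were characterised in a physicochemical assay for acid dissociation. Compound 2 gives 9.47 and compound 1 gives 9.28; these two numbers lie within the scatter of each other, so neither compound can be set apart from the other on this read-out. Compound 3 `COc1ccc(F)cc1CNCCCNc1ccnc2cc(CC3CCCCC3)ccc12` has not yet been measured in this assay. It differs from compound 2 in one place: 5-fluoro-2-methoxyphenyl in place of furan-2-yl on a saturated chain carbon bound to an amine nitrogen. The amine nitrogen itself and the rest of the chain and core are kept. Compound 1 already carries the 5-fluoro-2-methoxybenzyl piece on an amine nitrogen of this kind and gives 9.28, which is close to the number for compound 2, so the exchange is expected to move the read-out little. The step of a number 0.17 log units lower from compound 2 to compound 3 (within the scatter) is expected to stay within the scatter, leaning slightly downward if anywhere. Compound 3 is therefore estimated at 9.3, with a range from 8.9 to 9.7.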

Compound 3, acid dissociation constant: 9.47
Estimate against measurement, compound 3: 0.17 log units below; the measured number falls inside the stated range.
By their numbers in this assay, from the lowest: compounds 1, 2 and 3 (each within the scatter of the next).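

In this assay the exchange of furan-2-yl for 5-fluoro-2-methoxyphenyl on a saturated chain carbon bound to an amine nitrogen gives no change at the digits printed from compound 2 to compound 3 (within the scatter) and thus shows that, with the rest of compound 2 kept, a five-membered aromatic ring with one hetero atom and a six-membered aromatic ring of carbon only cannot be told apart on this read-out. The second step adds a change at another place: cyclohexylmethyl in place of 4-methoxyphenoxy on an aromatic carbon gives a number 0.19 log units higher from compound 1 to compound 3 (within the scatter) and so also stays inside the usual spread of repeat measurements. No measured property of these groups is available to account for either step.

Both groups exchanged on the chain carbon are aromatic rings, so the compounds shown leave open whether a non-aromatic group there, such as a cyclohexyl ring or a ring carrying an extra amine, would give a number clearly set apart from these. They also leave open whether a longer chain in place of the one joining the two nitrogens would shift the number in this assay.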